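From methoxy to allyloxy: a small expected step

A few compounds are considered here, and "the series" means these few. Any claim that something is new, unique, unknown or untested is made for them only; others in the source may bear on it.

- Compound 1 `CCOC(=O)c1c(C)nc(-c2cccc(C#N)c2)n1OC` gives 9130 nM
- Compound 2 `C=CCOn1c(-c2cccc(C#N)c2)nc(C)c1C(=O)OCC` gives 5860 nM
- Compound 3 `COn1c(-c2cccc(C#N)c2)nc(C)c1C(=O)O` gives 7990 nM

In a functional assay on a cell-free system (plasma, Oryctolagus cuniculus) for inhibition, with stated times of 5 min, 1 min and 6 min (on this read-out higher numbers stand for weaker inhibition and lower numbers for stronger inhibition), compound 3 gives 7990 nM, within the usual scatter of both other compounds. Compound 4 `C=CCOn1c(-c2cccc(C#N)c2)nc(C)c1C(=O)O` has vinyl in place of hydrogen on a saturated chain carbon bound to an oxygen on an aromatic ring, which turns methoxy to allyloxy (vinyl in place of hydrogen on a saturated chain carbon bound to an oxygen on an aromatic ring). The same change has been measured once: a 1.6-fold lower number from compound 1 to compound 2 (0.19 log units; within the scatter). Removing the ethyl group alone gave a 1.1-fold lower number from compound 1 to compound 3 (0.06 log units; within the scatter), so the earlier step offers the best guide here. The expected step is therefore small, toward a lower number, and not beyond the scatter: a 1.5-fold lower number from compound 3 to compound 4 (0.18 log units; within the scatter). For compound 4 the estimated value is 5300 nM, with an expected range from 3000 nM to 9500 nM.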

Compound 4, half-maximal inhibitory concentration: 6350 nM
Beside the measured number, compound 4's estimate is 1.2-fold (0.08 log units) below it; the measured number falls inside the stated range.
By their numbers in this assay, from the lowest: compounds 2, 4, 3 and 1 (each within the scatter of the next).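

Among these compounds, the change from methoxy to allyloxy can now be read on a second core, the one without the ethyl group, and gives a 1.3-fold lower number from compound 3 to compound 4 (0.10 log units; within the scatter). This step agrees with the earlier one: the same change on two cores in this assay, a 1.6-fold lower number (0.19 log units; within the scatter) from compound 1 to compound 2 and a 1.3-fold lower number (0.10 log units; within the scatter) from compound 3 to compound 4, 1.2-fold (0.09 log units) apart, within the scatter of two such steps. Removing the ethyl group can also be read a second time, now with allyloxy in place, and gives a 1.1-fold higher number from compound 2 to compound 4 (0.03 log units; within the scatter), which agrees with its earlier reading too: the same change on two cores in this assay, a 1.1-fold lower number (0.06 log units; within the scatter) from compound 1 to compound 3 and a 1.1-fold higher number (0.03 log units; within the scatter) from compound 2 to compound 4, 1.2-fold (0.09 log units) apart, within the scatter of two such steps.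

All of these steps stay within the scatter, so the compounds shown reveal no clear effect of either change. Going by these compounds, whether a longer chain such as hexyloxy in place of allyloxy, or an amide in place of the ester, would move the number beyond the scatter remains open.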